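Thiophene substituent swap on a sulfonylurea: compound 2 to compound 4

A few compounds are considered here, and "the series" means these few. Any claim that something is new, unique, unknown or untested is made for them only; others in the source may bear on it.

Compound 2 `CCc1ccc(S(=O)(=O)NC(=O)Nc2ccc(Cl)cc2)s1` gives 89% in a functional assay on the whole organism (6C3HED cells, Mus musculus) for inhibition, at a dose of 300 mg/kg by the oral route (on this read-out lower numbers stand for less inhibition and higher numbers for more inhibition at the one dose given (going by the name of the read-out)), and stands highest of the three measured numbers. Compound 1 `CSc1ccc(S(=O)(=O)NC(=O)Nc2ccc(Cl)cc2)s1` gives 62%, and compound 3 `CCCOc1ccc(S(=O)(=O)NC(=O)Nc2ccc(Cl)cc2)s1` gives 63%. Both neighbours sit beyond the scatter below compound 2: a number 27 percentage points higher from compound 1 to compound 2 (beyond the scatter) and a number 26 percentage points lower from compound 2 to compound 3 (beyond the scatter), whereas a number 1 percentage points higher from compound 1 to compound 3 (within the scatter).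

Compound 4 `Cc1ccsc1S(=O)(=O)NC(=O)Nc1ccc(Cl)cc1` is the unmeasured member, differing from compound 2 by 3-methylthiophen-2-yl in place of 5-ethylthiophen-2-yl on a sulfonyl sulfur. Within the data shown here, no measured step alters the thiophene in this way; the two steps that do bear on it, from compound 1 and from compound 3, each replace only the group on the ring and each lie beyond the scatter. Among the measured compounds shown here, those steps suggest that leaving the ethyl pattern of compound 2 tends to cost inhibition, so a downward step is expected, though on only two comparisons the size is uncertain. Compound 4 is estimated at 63%, between 38% and 85%, meaning an expected step of a number 26 percentage points lower from compound 2 to compound 4 (beyond the scatter).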

Compound 4, a percentage reported as inhibition, in the whole organism at one dose (the size of the read-out at that dose, not a potency): 62%
For compound 4 the middle estimate is 1 percentage points above the measured one; the measured number falls inside the stated range.
By their numbers in this assay, from the lowest: compounds 1, 4 and 3 (each within the scatter of the next); then compound 2.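

In this assay, 3-methylthiophen-2-yl in place of 5-ethylthiophen-2-yl on the sulfonyl sulfur gives a number 27 percentage points lower from compound 2 to compound 4 (beyond the scatter), so compound 2 now stands beyond the scatter above all three other thiophene groups shown, including one that is named with its substituent at 3 rather than 5. Replacing 5-(methylsulfanyl)thiophen-2-yl with 3-methylthiophen-2-yl gives no change at the digits printed from compound 1 to compound 4 (within the scatter), so this read-out does not separate these two groups at this place on the sulfonyl sulfur. Nothing available explains either step.

A 5-methylthiophen-2-yl or 3-ethylthiophen-2-yl group would separate the effect of the ethyl group from that of its place on the thiophene. A 5-propylthiophen-2-yl group would show whether a longer chain keeps the number of compound 2.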